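The source may report more compounds than this note shows. Statements on the series, on what has been measured and on what is new or still open speak of the compounds shown alone.

Measured compounds:
- compound 1, `O=C(N/N=C/c1cccc(Cl)c1)c1cnccn1`: 100%
- compound 2, `O=C(N/N=C/c1ccc(F)cc1)c1cnccn1`: 71%
- compound 3, `CN(C)c1ccc(/C=N/NC(=O)c2cnccn2)cc1`: 89%

These three compounds share one core and differ only in the group carried on the outer benzene ring. They were tested in an ADME assay on J774 cells (Mus musculus) for cytotoxicity, read by MTT assay, with a stated time of 48 h, tested at 150 ug/mL; on this read-out higher numbers stand for a weaker effect at the one concentration tested and lower numbers for a stronger effect. Compound 1 gives 100%, the highest of the three numbers; compound 3 sits nearest to it with 89%, and compound 2 furthest away with 71%, both gaps beyond the scatter.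

The unmeasured compound 4, `O=C(N/N=C/c1cccc([N+](=O)[O-])c1)c1cnccn1`, is reached from compound 1 by one change: nitro in place of chloro on an aromatic carbon. The place is an aromatic carbon of a six-membered aromatic ring of carbon only, meta to a large group.

Within the data shown here, only one step between measured compounds exists, and it is of a different kind: a number 18 percentage points higher from compound 2 to compound 3 (beyond the scatter). It concerns a dimethylamino group in place of a fluoro group, not a nitro group in place of a chloro group, so it offers no direct guide. It does show that swapping one substituent on this ring for another moves the read-out only modestly. Given that, compound 4 is expected to stay close to compound 1, with a small downward step at most, a number 10 percentage points lower from compound 1 to compound 4 (within the scatter). The estimate for compound 4 is therefore 90%, within 68% to 105%.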

Compound 4, a percentage reported as activity, at one concentration (the size of the read-out at that concentration, not a potency): 76%
Compound 4: middle estimate off by 14 percentage points, on the high side; low and high end bracket the measured number.
By their numbers in this assay, from the lowest: compounds 2 and 4 (each within the scatter of the next); then compound 3; then compound 1.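

In this assay, putting nitro in place of chloro on this aromatic carbon, meta to a large group, gives a number 24 percentage points lower from compound 1 to compound 4 (beyond the scatter), so the cells are affected more strongly at the one concentration tested. The earlier compounds shown here showed a shift only for dimethylamino in place of fluoro; this result shows that the read-out also responds to a change at this position, and that the swap of chloro for nitro is not a silent one. The change replaces one heavy atom and no hydrogen-bond acceptors with three heavy atoms and two hydrogen-bond acceptors, but nothing available here separates these differences or explains the shift.

The compounds shown leave open how an amine, a carboxylic acid or a methoxy group on this same carbon would read in this assay. They also leave open whether nitro would give a step of similar size on another carbon of the ring, so the step cannot yet be told apart as a feature of the group or of its place.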